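This account rests on a few compounds, and the source may have more. Where it says the series, first, only, none or still open, it means among the compounds named here.

Measured in a functional assay (trachea) with Cavia porcellus as the target; a higher number here means that more compound is needed for the effect, a lower number that less compound is needed:
- compound 1 `CCCn1c(=O)n(CCC(N)=O)c(=O)c2[nH]cnc21`: 13100 nM
- compound 2 `CCCn1c(=O)n(C)c(=O)c2c1ncn2CC(N)=O`: > 100000 nM

Compound 2 has no number, only a limit: the limit of > 100000 nM in this assay, at which 1 of the 2 values shown sits.

Compound 3 `CCCn1c(=O)n(C)c(=O)c2c1ncn2CCCN(C)C` carries 2-(dimethylamino)ethyl in place of carbamoyl on a saturated chain carbon bound to an aromatic nitrogen.

Within the data shown here, no measured step covers this change, so the expectation is loose. Compound 1 at 13100 nM shows that a numeric value is possible in this small series. A move to a lower number in this assay is expected, with the estimated step being an at least 3.3-fold lower number from compound 2 to compound 3 (0.52 log units; beyond the scatter). Compound 3 is expected at 30000 nM, with an estimated range of 8000 nM to 100000 nM.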

Compound 3, half-maximal effective concentration: > 100000 nM
Compound 3: only a limit was reported (the forecaster's own chance of this, stated with the estimate: 35%); at least 3.3-fold (0.52 log units) between middle value and limit.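

For compound 2 and compound 3 only limits stand in this assay, and no step can be read between them. Still open, from the compounds shown here alone, is whether any chain at this place gives a numeric value in this assay.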